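Methoxy to Ethoxy Repeated on a Second Core

The source may report more compounds than this note shows. Statements on the series, on what has been measured and on what is new or still open speak of the compounds shown alone.

Compound 1 `COc1ccccc1/C=C/c1nc2ccccc2c(=O)[nH]1` and compound 2 `COc1ccc(/C=C/c2nc3ccccc3c(=O)[nH]2)cc1` are built from the same atoms joined differently; the difference between the two cores is not broken down here. In a functional assay on HCT-116 cells (Homo sapiens) for antiproliferative activity, with a stated time of 72 h (on this read-out higher numbers stand for weaker inhibition and lower numbers for stronger inhibition), compound 1 gives 1460 nM. Compound 2 gives only a limit of the assay in this assay, namely > 25000 nM. Compound 3 `CCOc1ccccc1/C=C/c1nc2ccccc2c(=O)[nH]1` differs from compound 1 by methyl in place of hydrogen on a saturated chain carbon bound to an oxygen on an aromatic ring; in this assay compound 3 gives 6430 nM, so the step of a 4.4-fold higher number from compound 1 to compound 3 (0.64 log units; beyond the scatter) points toward weaker inhibition. Compound 4 `CCOc1ccc(/C=C/c2nc3ccccc3c(=O)[nH]2)cc1` carries the same change on the other core, (methyl in place of hydrogen on a saturated chain carbon bound to an oxygen on an aromatic ring). Because compound 2 already sits at the limit of > 25000 nM in this assay, at which 1 of the 3 values shown sits, a step of the same direction would be expected to keep compound 4 at a limit. The step expected from compound 2 to compound 4 is estimated as a step that the limit leaves unreadable from compound 2 to compound 4, resting on the measured step from compound 1 to compound 3. Compound 4 is therefore expected to give about 60000 nM in this assay, between 20000 nM and 250000 nM.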

Compound 4, half-maximal inhibitory concentration: > 25000 nM
Compound 4 ended at the assay's limit; the forecaster's own chance of this, stated with the estimate: 85%; the middle value does not contradict the limit.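

Compound 2 and compound 4 both end at a limit of the assay, so no step between them can be read: the limit of > 25000 nM in this assay, at which 2 of the 4 values shown sit.

On these data alone, whether methoxy to ethoxy changes inhibition on the core of compound 2, as it does on the core of compound 1, stays open.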